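A few compounds are considered here, and "the series" means these few. Any claim that something is new, unique, unknown or untested is made for them only; others in the source may bear on it.

Working notes on the series. Among the compounds with values here, compound 2 `N#Cc1cnc(NCc2cnccc2C(F)(F)F)cc1NCC1CCOCC1` gives 400 nM in an assay on isolated protein for inhibition of protein kinase C theta type (Homo sapiens), read by TR-FRET, with a stated time of 2 h (a higher number here means a weaker inhibitor, a lower number a stronger inhibitor), the highest of the two numbers so far; its nearest neighbour is compound 1 `N#Cc1cnc(NCc2cnccc2C(F)(F)F)cc1NC[C@H]1CC[C@@H](O)CC1`, which gives 58 nM in this assay. Within the data shown here, the single measured step, a 6.9-fold higher number from compound 1 to compound 2 (0.84 log units; beyond the scatter), shows that oxan-4-yl in place of 4-hydroxycyclohexyl costs potency. Compound 3 `CC1(C)C[C@H](Nc2cc(NCc3cnccc3C(F)(F)F)ncc2C#N)CC[C@H]1O` undoes part of that change: 4-hydroxy-3,3-dimethylcyclohexyl in place of (oxan-4-yl)methyl on a nitrogen on an aromatic ring. Among the measured compounds shown here, the hydroxyl-bearing six-membered ring of carbon only returns, now as the 3,3-dimethyl variant and bound to the aromatic nitrogen without the chain carbon; no measured step covers the dimethyl or the missing chain carbon. For the measured compounds named here, the step of a 6.9-fold higher number from compound 1 to compound 2 (0.84 log units; beyond the scatter) is the only guide, and it argues for a move back toward compound 1. The expected step of a 4.4-fold lower number from compound 2 to compound 3 (0.65 log units; beyond the scatter) is therefore a decrease, with wide uncertainty. Compound 3 is estimated at 90 nM in this assay, with a range of 25 nM to 320 nM.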

Compound 3, half-maximal inhibitory concentration: 100 nM
Beside the measured number, compound 3's estimate is 1.1-fold (0.05 log units) below it; the range from low to high includes it.
By their numbers in this assay, from the lowest: compounds 1 and 3 (each within the scatter of the next); then compound 2.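

On a nitrogen on an aromatic ring, 4-hydroxy-3,3-dimethylcyclohexyl in place of (oxan-4-yl)methyl gives a 4.0-fold lower number from compound 2 to compound 3 (0.60 log units; beyond the scatter), so a hydroxylated six-membered ring of carbon only restores potency without the chain carbon that compound 1 carries. Against (4-hydroxycyclohexyl)methyl, the same group gives a 1.7-fold higher number from compound 1 to compound 3 (0.24 log units; within the scatter), so in this assay compound 1 and compound 3 cannot be told apart, even though the two groups differ in both the chain carbon and the dimethyl pair. No evidence on hand bears on the reason for either step.

The contributions of the dimethyl pair and the chain carbon remain unseparated, since they change together in these compounds. Also open, on these data alone, is how an amine, as in 4-aminocyclohexyl, or a carboxylic acid in place of the hydroxy group would read at this nitrogen.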